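The source may report more compounds than this note shows. Statements on the series, on what has been measured and on what is new or still open speak of the compounds shown alone.

Measured compounds:
- compound 1 `CNC(=O)N1CCCc2ccc(NC(=O)c3cccc(-c4ccn(C(C)=O)n4)c3)cc21`: 87.6%
- compound 2 `CNC(=O)N1CCCc2ccc(NC(=O)c3ccc(-c4ccncc4)cc3)cc21`: 88.7%
- compound 3 `CNC(=O)N1CCCc2ccc(NC(=O)c3ccc(-c4ccn(C)n4)cc3)cc21`: 97%

All three share one core and were tested in a functional assay on MV4-11 cells (Homo sapiens) for antiproliferative activity, with a stated time of 6 days, tested at 6.25 uM; on this read-out higher numbers stand for a stronger effect at the one concentration tested and lower numbers for a weaker effect. Compound 2 sits between the other two, and both gaps lie within the scatter: compound 1 gives a number close below it, and a number 8.3 percentage points higher from compound 2 to compound 3 (within the scatter).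

Compound 4 `CNC(=O)N1CCCc2ccc(NC(=O)c3ccc(-c4ccccc4)cc3)cc21` has not yet been measured. It differs from compound 2 in one place: phenyl in place of pyridin-4-yl on an aromatic carbon.

Among the compounds with values here, only one measured step changes the same position, the step from compound 2 to compound 3, which exchanged the same leaving group for a different entering group and stayed within the scatter. Within the data shown here, no measured step puts phenyl in that place, so the expectation rests on that single step alone. Since a change at this position has so far moved the read-out by no more than the scatter, the step from compound 2 to compound 4 is expected to be small as well, with no clear direction: a number 1.7 percentage points lower from compound 2 to compound 4 (within the scatter).

Compound 4 is therefore estimated to give 87% in this assay, with a range from 70% to 97%.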

Compound 4, a percentage reported as inhibition, at one concentration (the size of the read-out at that concentration, not a potency): 74.3%
The estimate for compound 4 lay 12.7 percentage points above the measured number; measured number inside the range.
By their numbers in this assay, from the lowest: compound 4; then compounds 1, 2 and 3 (each within the scatter of the next).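

In this assay, within the data shown here, this position proves sensitive to the choice of ring: exchanging pyridin-4-yl for phenyl keeps the ring size and heavy-atom count but gives a number 14.4 percentage points lower from compound 2 to compound 4 (beyond the scatter), the first change here to go beyond the scatter. Replacing 1-methyl-1H-pyrazol-3-yl with phenyl gives a larger drop, a number 22.7 percentage points lower from compound 3 to compound 4 (beyond the scatter), so at this place both groups with ring nitrogen give higher numbers than the carbon-only ring. Nothing available gives a reason for these drops.

The compounds shown leave open whether the ring nitrogen itself accounts for the difference or whether any group carrying a hydrogen-bond acceptor would do the same. A phenyl bearing a methoxy group or an amine, or a pyridin-3-yl ring at the same place, would help to separate these possibilities.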